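The compounds below may be only part of what the source reports. "The series", "measured", "known", "first", "only" and "open" are said of these compounds alone.

In a functional assay on BGC-823 cells (Homo sapiens) for inhibition, read by CCK-8 assay, with a stated time of 48 h (on this read-out lower numbers stand for stronger inhibition and higher numbers for weaker inhibition), compound 3 `Fc1ccc(C2=NN(C3=NC(c4ccccc4)CS3)C(c3cccc4ccccc34)C2)cc1` gives 22700 nM, the highest of the three numbers seen; compound 2 `c1ccc(C2=NN(C3=NC(c4ccccc4)CS3)C(c3cccc4ccccc34)C2)cc1` gives 14300 nM and compound 1 `COc1ccc(C2=NN(C3=NC(c4ccccc4)CS3)C(c3cccc4ccccc34)C2)cc1` gives 9510 nM. Compound 4 `Cc1ccc(C2=NN(C3=NC(c4ccccc4)CS3)C(c3cccc4ccccc34)C2)cc1C` differs from compound 3 by 3,4-dimethylphenyl in place of 4-fluorophenyl on a carbon with a double bond to nitrogen. For the measured compounds named here, no measured step makes this exact change. The nearest are a 1.6-fold higher number from compound 2 to compound 3 (0.20 log units; within the scatter), a 2.4-fold higher number from compound 1 to compound 3 (0.38 log units; beyond the scatter) and a 1.5-fold higher number from compound 1 to compound 2 (0.18 log units; within the scatter), so swapping groups at this position has so far moved the number only modestly, and only the methoxy of compound 1 went beyond the scatter. A modest step toward a lower number is therefore expected, a 1.9-fold lower number from compound 3 to compound 4 (0.28 log units; within the scatter). Compound 4 is estimated at 12000 nM, with a range from 5000 nM to 30000 nM.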

Compound 4, half-maximal inhibitory concentration: 8460 nM
Compound 4: the middle estimate sits 1.4-fold (0.15 log units) above what was measured; low and high end bracket the measured number.
By their numbers in this assay, from the lowest: compounds 4, 1, 2 and 3 (each within the scatter of the next, the first and the last beyond it).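

In this assay, 3,4-dimethylphenyl joins 4-methoxyphenyl as a group that stands beyond the scatter from 4-fluorophenyl, with a 2.7-fold lower number from compound 3 to compound 4 (0.43 log units; beyond the scatter). Against phenyl, with a 1.7-fold lower number from compound 2 to compound 4 (0.23 log units; within the scatter) and against 4-methoxyphenyl, with a 1.1-fold lower number from compound 1 to compound 4 (0.05 log units; within the scatter), it stays within the scatter, so a ring carrying only carbon substituents cannot be told apart from the methoxy one here. No evidence is available to explain this result. The compounds shown leave open whether an amine or a carboxylic acid on this phenyl ring would move the number, and whether a longer chain would do so in place of the methyl groups.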